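The source may report more compounds than this note shows. Statements on the series, on what has been measured and on what is new or still open speak of the compounds shown alone.

In a functional assay on MCF7 cells (Homo sapiens) for antiproliferative activity, read by MTT assay, with a stated time of 72 h (on this read-out higher numbers stand for weaker inhibition and lower numbers for stronger inhibition), compound 3 (`CCCNC(=O)c1cc(Oc2ccc(NC(=O)c3nn(-c4ccc(Br)cc4F)c(=O)cc3C)cc2F)ccn1`) is reported as "not active" (no number reported) and carries no number, so it has no exact place on the scale. Two related compounds do give numbers: compound 1 (`CCNC(=O)c1cc(Oc2ccc(NC(=O)c3nn(-c4ccccc4OC(F)(F)F)c(=O)cc3C)cc2)ccn1`) reads 15500 nM and compound 2 (`CCCNC(=O)c1cc(Oc2ccc(NC(=O)c3nn(-c4ccc(C)cc4)c(=O)cc3C)cc2F)ccn1`) reads 34600 nM as measured values. Compound 4 (`CCCNC(=O)c1cc(Oc2ccc(NC(=O)c3nn(-c4ccccc4OC(F)(F)F)c(=O)cc3C)cc2F)ccn1`) differs from compound 3 in one place (2-(trifluoromethoxy)phenyl in place of 4-bromo-2-fluorophenyl on an aromatic nitrogen), with 2-(trifluoromethoxy)phenyl in place of 4-bromo-2-fluorophenyl on an aromatic nitrogen. Compound 1 carries the same entering group but differs elsewhere as well. In this assay a step towards stronger inhibition is expected, of a size that cannot be stated without a number for compound 3, and another report without a number remains possible. Compound 4 is estimated at 20000 nM (expected range 8000 nM to 50000 nM).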

Compound 4, half-maximal inhibitory concentration: 7420 nM
Beside the measured number, compound 4's estimate is 2.7-fold (0.43 log units) above it, and the stated range ends above it.
By their numbers in this assay, from the lowest: compound 4; then compound 1; then compound 2.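

In this assay, the group on the aromatic nitrogen now has a measured effect, with 2-(trifluoromethoxy)phenyl replacing 4-methylphenyl giving a 4.7-fold lower number from compound 2 to compound 4 (0.67 log units; beyond the scatter) on an otherwise unchanged compound. The step from compound 3 to compound 4 cannot be read, as compound 3 carries no number, though compound 4 gives a value where compound 3 was reported as not active. Nothing available offers a reason for the measured step.

Among these compounds, only this one step has numbers at both ends, so it rests on a single pair. From the compounds shown here alone, whether an amine or a carboxylic acid on the phenyl ring at this position would lower the number further remains open.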